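Chloro at the chain end of compound 3

This account rests on a few compounds, and the source may have more. Where it says the series, first, only, none or still open, it means among the compounds named here.

Three analogues share one core. Compound 1 `O=c1[nH]c(=O)n(CCC(CO)CO)cc1-c1ccco1` sits at a limit in a functional assay on MCF7 cells (Homo sapiens) for antiproliferative activity, read by MTT assay, with a stated time of 72 h (on this read-out lower numbers stand for stronger inhibition and higher numbers for weaker inhibition), giving < 10 nM. Compound 2 `O=c1[nH]c(=O)n(CCC(CO)CO)cc1C#CC1CC1` likewise sits at a limit in this assay, giving > 100000 nM. Going by the values given here, compound 3 `CCCCCC#Cc1cn(CCC(CO)CO)c(=O)[nH]c1=O` is the only one with an actual number in this assay, giving 37800 nM. The steps from compound 1 are large: an at least 10000-fold higher number from compound 1 to compound 2 (4.00 log units; beyond the scatter) and an at least 3700-fold higher number from compound 1 to compound 3 (3.57 log units; beyond the scatter). The step between the two chains on a triple-bonded carbon, an at least 2.6-fold lower number from compound 2 to compound 3 (0.42 log units; beyond the scatter), is far smaller. Compound 4 `O=c1[nH]c(=O)n(CCC(CO)CO)cc1C#CCCCCl` differs from compound 3 by chloro in place of ethyl on a saturated chain carbon, three bonds along the chain from a triple-bonded carbon. Among the compounds with values here, only the step between chains bears on this, and it was modest, so the expected change in this assay is small. The expected step is a 1.1-fold higher number from compound 3 to compound 4 (0.02 log units; within the scatter). Compound 4 is therefore estimated at 40000 nM, within 10000 nM to 150000 nM.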

Compound 4, half-maximal inhibitory concentration: 35200 nM
Compound 4: middle estimate off by 1.1-fold (0.06 log units), on the high side, and the stated range covers the measured number.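

In this assay, chloro in place of ethyl on a saturated chain carbon, three bonds along the chain from a triple-bonded carbon, gives a 1.1-fold lower number from compound 3 to compound 4 (0.03 log units; within the scatter), so this end of the chain takes the swap without a step beyond the scatter. The two other steps, an at least 2.8-fold lower number from compound 2 to compound 4 (0.45 log units; beyond the scatter) and an at least 3500-fold higher number from compound 1 to compound 4 (3.54 log units; beyond the scatter), each start from a limit and not from a number. The chloro-ended chain therefore stays far from furan-2-yl.

As far as these compounds go, whether an amine or a carboxylic acid at the chain end would behave as chloro does remains open. So does the effect of a longer chain.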